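Benzyl to 4-nitrophenyl on compound 1

The compounds below may be only part of what the source reports. "The series", "measured", "known", "first", "only" and "open" are said of these compounds alone.

In an ADME assay on HEK-293T cells (Homo sapiens) for cytotoxicity, read by CCK-8 assay, with a stated time of 48 h (on this read-out lower numbers stand for stronger inhibition and higher numbers for weaker inhibition), compound 1 (`O=S(=O)(NCCNC(=S)Nc1cccc(Cl)c1)c1ccc(-c2ccccc2OCc2ccccc2)s1`) gives 10200 nM and compound 2 (`O=[N+]([O-])c1cccc(NC(=S)NCCNS(=O)(=O)c2ccc(-c3ccccc3OCc3ccccc3)s2)c1`) gives 18300 nM on the same read-out. Within the data shown here, the two numbers lie within the usual scatter of each other, so compound 1 stands level with the only other measured compound. Compound 3 (`O=[N+]([O-])c1ccc(Oc2ccccc2-c2ccc(S(=O)(=O)NCCNC(=S)Nc3cccc(Cl)c3)s2)cc1`) keeps the core of compound 1 and differs from it at one place (4-nitrophenyl in place of benzyl on an oxygen on an aromatic ring), with 4-nitrophenyl in place of benzyl on an oxygen on an aromatic ring. Among the measured compounds shown here, the one measured step, nitro in place of chloro on an aromatic carbon, is a 1.8-fold higher number from compound 1 to compound 2 (0.25 log units; within the scatter) and does not touch that oxygen. It therefore bears only loosely on this change and gives no direction. No step beyond the scatter is expected in this assay for this change. The estimated step of a 1.0-fold lower number from compound 1 to compound 3 (0.01 log units; within the scatter) is expected to stay within the scatter. Compound 3 is expected at 10000 nM with an estimated range of 4000 nM to 25000 nM once measured.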

Compound 3, half-maximal inhibitory concentration: 4990 nM
Compound 3: the middle estimate sits 2.0-fold (0.30 log units) above what was measured; measured number inside the range.
By their numbers in this assay, from the lowest: compound 3; then compounds 1 and 2 (each within the scatter of the next).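

In this assay the exchange of benzyl for 4-nitrophenyl on the oxygen gives a 2.0-fold lower number from compound 1 to compound 3 (0.31 log units; beyond the scatter) as a modest step, yet one beyond the scatter. Among these compounds, the earlier change, nitro in place of chloro on an aromatic carbon, gave a 1.8-fold higher number from compound 1 to compound 2 (0.25 log units; within the scatter) and stayed within the scatter, so this oxygen is the first place where a single change moves the number beyond it. Nothing measured here accounts for the shift.

The compounds shown cannot separate the part played by the nitro group from that of replacing benzyl with an aromatic ring bearing it, and a plain phenyl or an aminophenyl on that oxygen would be needed to tell them apart. Going by these compounds, it also stays open whether the same step would appear on the background of compound 2.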